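A few compounds are considered here, and "the series" means these few. Any claim that something is new, unique, unknown or untested is made for them only; others in the source may bear on it.

Compound 1, `O=C(Nc1ccccc1)c1cc(Oc2ccc(/C=C/c3ccccn3)cc2)ccn1`: 30200 nM
Compound 2, `COc1ccc(NC(=O)c2cc(Oc3ccc(/C=C/c4ccccn4)cc3)ccn2)cc1`: 30000 nM
Compound 3, `O=C(Nc1ccc(Cl)cc1)c1cc(Oc2ccc(/C=C/c3ccccn3)cc2)ccn1`: 31300 nM

All three compounds were tested in a functional assay on HepG2 cells (Homo sapiens) for antiproliferative activity, read by CCK-8 assay, with a stated time of 48 h; a lower number here means a stronger inhibitor, a higher number a weaker inhibitor. Compound 3 gives the highest of the three numbers, but the step of a 1.0-fold higher number from compound 1 to compound 3 (0.02 log units; within the scatter) and the step of a 1.0-fold higher number from compound 2 to compound 3 (0.02 log units; within the scatter) both lie within the scatter, so compound 3 cannot be called weaker than the other two. The step of a 1.0-fold lower number from compound 1 to compound 2 (0.00 log units; within the scatter) is likewise within the scatter; on the numbers shown, the three compounds are indistinguishable.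

Compound 4, `O=C(NCc1ccccc1)c1cc(Oc2ccc(/C=C/c3ccccn3)cc2)ccn1`, has not yet been measured. It differs from compound 3 in one place: benzyl in place of 4-chlorophenyl on an amide-type nitrogen. Among the measured compounds shown here, none of the measured steps bears directly on this change; each of them concerns a methoxy or a chloro in place of hydrogen on an aromatic carbon, and each was within the scatter. The exchange of 4-chlorophenyl for benzyl is a change of a different kind, for which the measured compounds give no direct guide. Compound 4 is therefore expected to give about 30000 nM in this assay, within 9000 nM to 100000 nM. The expected step of a 1.0-fold lower number from compound 3 to compound 4 (0.02 log units; within the scatter) is thus none beyond the scatter, with a wide range reflecting the absence of a comparable measured step.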

Compound 4, half-maximal inhibitory concentration: 27900 nM
Compound 4: middle estimate off by 1.1-fold (0.03 log units), on the high side; measured number inside the range.
By their numbers in this assay, from the lowest: compounds 4, 2, 1 and 3 (each within the scatter of the next).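

In this assay, the amide-type nitrogen tolerates a change of a different kind from the earlier methoxy and chloro exchanges on the aromatic ring. Benzyl in place of 4-chlorophenyl (a 1.1-fold lower number from compound 3 to compound 4 (0.05 log units; within the scatter)), 4-methoxyphenyl (a 1.1-fold lower number from compound 2 to compound 4 (0.03 log units; within the scatter)) or phenyl (a 1.1-fold lower number from compound 1 to compound 4 (0.03 log units; within the scatter)) leaves all four compounds within the scatter of one another, so replacing the aryl group on this nitrogen with benzyl does not separate them any more than the substituents did. No measurement shown explains why the numbers stay together.

On these data alone, it remains open whether a longer chain carrying the phenyl ring, such as phenethyl, or a basic amine or carboxylic acid on that ring would move the number beyond the scatter. Also open, as far as these compounds go, is whether any change elsewhere in the shared core would do so.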